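The source may report more compounds than this note shows. Statements on the series, on what has been measured and on what is new or still open speak of the compounds shown alone.

Compound 1 `COC/C1=C/C[C@](C)(CCC=C(C)C)/C=C/[C@@H](OC(=O)C=C(C)C)[C@](C)(OC)/C=C/C1=O`: 16500 nM
Compound 2 `C=C1/C=C/C(=O)/C(CO)=C\C[C@](C)(CCC=C(C)C)/C=C/[C@H]1OC(=O)C=C(C)C`: 2750 nM
Compound 3 `CC(C)=CCC[C@]1(C)/C=C/[C@@H](OC(=O)C=C(C)C)[C@](C)(O)/C=C/C(=O)/C(C=O)=C\C1`: 12600 nM

Of the compounds shown here, three have been tested in a functional assay on MCF7 cells (Homo sapiens) for antiproliferative activity, read by MTT assay, with a stated time of 48 h; a lower number here means a stronger inhibitor, a higher number a weaker inhibitor. Compound 3 stands second highest of the three numbers: its value sits close to that of compound 1, within the usual scatter, while compound 2 gives a number well below both, a gap that lies beyond the scatter.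

Compound 4 `CC(C)=CCC[C@]1(C)/C=C/[C@@H](OC(=O)C=C(C)C)[C@](C)(O)/C=C/C(=O)/C(Cn2cc(CO)nn2)=C\C1` has not been measured yet. It is built from compound 3 by one change: (4-(hydroxymethyl)-1H-1,2,3-triazol-1-yl)methyl in place of formyl on a double-bonded ring carbon. Among the measured compounds shown here, no step between two measured compounds isolates a change of this kind, so there is no direct guide to its size. The expectation is therefore a step from compound 3 to compound 4 that stays close to the scatter, if anything towards a higher number, that is a 1.2-fold higher number from compound 3 to compound 4 (0.08 log units; within the scatter) in this assay. On that basis compound 4 is estimated at 15000 nM, with a range from 5000 nM to 50000 nM.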

Compound 4, half-maximal inhibitory concentration: 2930 nM
Compound 4: the middle estimate sits 5.1-fold (0.71 log units) above what was measured, and the stated range ends above it.
By their numbers in this assay, from the lowest: compounds 2 and 4 (each within the scatter of the next); then compounds 3 and 1 (each within the scatter of the next).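

In this assay, the double-bonded ring carbon accepts a much larger group than formyl without any loss: putting (4-(hydroxymethyl)-1H-1,2,3-triazol-1-yl)methyl in place of formyl gives a 4.3-fold lower number from compound 3 to compound 4 (0.63 log units; beyond the scatter). This step lies beyond the usual scatter, so in this pair the formyl group is not needed for the activity seen, and the position can carry a five-membered aromatic ring on a one-carbon link. Nothing available here bears on why the number falls.

The compounds shown do not separate the part played by the ring from that of its hydroxymethyl group, which a plain methyl on the same ring could test. They also leave open how a simple aminomethyl group or a carboxylic acid would behave on this ring carbon.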